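Dichloropurine series: second chloro and benzyl attachment

The source may hold more compounds than are shown below. What is called first, only, known or untested is meant among the compounds shown, and "the series" means these compounds.

Three compounds have been run in a functional assay on OVCAR-5 cells (Homo sapiens) for cytotoxicity, read by sulforhodamine B assay, with a stated time of 48 h; on this read-out higher numbers stand for lower toxicity in this test and lower numbers for higher toxicity in this test. Compound 1 `ClCc1ccccc1Cn1cnc2c(Cl)nc(Cl)nc21` gives 5620 nM. Compound 2 `ClCc1ccccc1Cn1cnc2c(Cl)ncnc21` gives 25700 nM. Compound 3 `ClCc1cccc(Cn2cnc3c(Cl)ncnc32)c1` gives 8910 nM in this assay. Compound 1 and compound 2 share a core and differ by one change, (chloro in place of hydrogen on an aromatic carbon), which made the step of a 4.6-fold lower number from compound 2 to compound 1 (0.66 log units; beyond the scatter). Compound 3 and compound 2 have the same atoms joined differently; the difference between the two cores is not broken down here, and their values alone show a higher number for compound 2.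

Compound 4 `ClCc1cccc(Cn2cnc3c(Cl)nc(Cl)nc32)c1` has not yet been measured in this assay. It differs from compound 3 by chloro in place of hydrogen on an aromatic carbon, and the words around the place are the same as for the change from compound 2 to compound 1, so this is the same change, seen twice among these compounds. Among the measured compounds shown here, the one measured example, a 4.6-fold lower number from compound 2 to compound 1 (0.66 log units; beyond the scatter), is the only basis for expectation. Compound 4 is therefore expected to give a lower number than compound 3, with a step of about a 4.1-fold lower number from compound 3 to compound 4 (0.61 log units; beyond the scatter), because the earlier step was a 4.6-fold lower number from compound 2 to compound 1 (0.66 log units; beyond the scatter). Compound 4 is estimated at 2200 nM, with a range from 1000 nM to 5000 nM.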

Compound 4, concentration lethal to 50% of the cells: 47900 nM
Estimate against measurement, compound 4: 22-fold (1.34 log units) below; the whole stated range lies below it.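

In this assay, among the compounds shown here, chloro in place of hydrogen on an aromatic carbon gives a 5.4-fold higher number from compound 3 to compound 4 (0.73 log units; beyond the scatter), the opposite direction to the one step seen earlier. The two readings of this change do not agree: the same change on two cores in this assay, a 4.6-fold lower number (0.66 log units; beyond the scatter) from compound 2 to compound 1 and a 5.4-fold higher number (0.73 log units; beyond the scatter) from compound 3 to compound 4, 25-fold (1.39 log units) apart, beyond the scatter of two such steps

With only these two pairs, the notes can say that the step does not carry from one of these cores to the other, so a value for this change on a further core cannot be taken from either pair; they do not say which difference between the cores sets the direction, nor which of the two steps is more typical of the series.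

Still open, as far as these compounds go, is whether an amine or a methoxy group in place of the chloro between two ring nitrogen atoms would follow compound 1 or compound 4 on each core. Also open, from the compounds shown here alone, is whether a longer chain in place of the chloromethyl group would leave the split between the two cores in place.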